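A few compounds are considered here, and "the series" means these few. Any claim that something is new, unique, unknown or untested is made for them only; others in the source may bear on it.

Compound 1 `O=c1[nH]cc(S(=O)(=O)Nc2ccccc2-c2cn(-c3ccccc3F)nn2)c(=O)[nH]1` was tested in an ADME assay on L02 cells (Homo sapiens) for cytotoxicity, read by MTT assay, with a stated time of 24 h (a lower number here means that less compound is tolerated, a higher number that more compound is tolerated), where its reading of > 100000 nM is a limit of the assay and not a number. Compound 2 `Cc1ccc(-n2cc(-c3ccc(NS(=O)(=O)c4c[nH]c(=O)[nH]c4=O)cc3)nn2)cc1` is recorded in this assay only as "not toxic" (no number reported), with no figure given. Compound 2 therefore stands without a single number in this series. For the measured compounds named here, the one further value is the limit (the limit of > 100000 nM in this assay, at which 1 of the 2 values shown sits). Compound 3 `O=c1[nH]cc(S(=O)(=O)Nc2ccc(-c3cn(-c4ccccc4Cl)nn3)cc2)c(=O)[nH]1` remains to be measured in this assay. It differs from compound 2 by 2-chlorophenyl in place of 4-methylphenyl on an aromatic nitrogen. Going by the values given here, no measured step joins two compounds in this set, so the size of the change from compound 2 to compound 3 in this assay cannot be read from any measured pair; with one earlier value a limit and the other reported without a number, no movement beyond the scatter is expected in either direction. Compound 3 is expected to give about 150000 nM in this assay, estimated to fall between 50000 nM and 500000 nM, most likely reported again as a limit.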

Compound 3, half-maximal cytotoxic concentration: 19300 nM
Compound 3: middle estimate off by 7.8-fold (0.89 log units), on the high side; the measured number lies below the stated range.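

In this assay no new step can be read, since compound 2 carries no number and compound 1 differs from compound 3 in more than one place. The compounds shown leave open what 2-chlorophenyl in place of 4-methylphenyl alone does to the reading. Compound 1 stands at a limit of the assay, not a number: the limit of > 100000 nM in this assay, at which 1 of the 3 values shown sits.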